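Fluoro for hydrogen on the aryl ring: two occurrences

The source may hold more compounds than are shown below. What is called first, only, known or untested is meant among the compounds shown, and "the series" means these compounds.

Compound 1 `COc1cc2c(Oc3ccc(NC(=O)c4cc(-c5ccccc5)ccn4)cc3F)ccnc2cc1OCCCN1CCCC1` gives 1580 nM in a functional assay on A549 cells (Homo sapiens) for cytotoxicity, read by MTT assay, with a stated time of 72 h; on this read-out higher numbers stand for weaker inhibition and lower numbers for stronger inhibition. Going by the values given here, compound 2 `COc1cc2c(Oc3ccc(NC(=O)c4cc(-c5ccccc5F)ccn4)cc3F)ccnc2cc1OCCCN1CCCC1` differs from it by fluoro in place of hydrogen on an aromatic carbon and gives 430 nM in this assay, so that the step of a 3.7-fold lower number from compound 1 to compound 2 (0.57 log units; beyond the scatter) is the one measured instance of this change.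

Compound 3 `COc1cc2c(Oc3ccc(NC(=O)c4nccc(-c5ccc(F)cc5)n4)cc3F)ccnc2cc1OCCCN1CCN(C)CC1` carries a different core; the difference between the two cores is not broken down here. In this assay compound 3 gives 680 nM.

Compound 4 `COc1cc2c(Oc3ccc(NC(=O)c4nccc(-c5ccc(F)cc5F)n4)cc3F)ccnc2cc1OCCCN1CCN(C)CC1` differs from compound 3 by fluoro in place of hydrogen on an aromatic carbon. Against the earlier pair, the place of the entering fluoro is here also meta to a fluoro group, so this is the same kind of change rather than the same change, and the other core adds uncertainty.

Compound 4 is expected to lie below compound 3 in this assay, with an estimated step of a 2.3-fold lower number from compound 3 to compound 4 (0.36 log units; beyond the scatter), kept somewhat smaller because a 3.7-fold lower number from compound 1 to compound 2 (0.57 log units; beyond the scatter) was measured on a different core. The estimate for compound 4 is 300 nM, with a range from 120 nM to 800 nM.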

Compound 4, half-maximal inhibitory concentration: 660 nM
Compound 4: the middle estimate sits 2.2-fold (0.34 log units) below what was measured, within the range that was stated.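

In this assay, fluoro in place of hydrogen on an aromatic carbon gives a 1.0-fold lower number from compound 3 to compound 4 (0.01 log units; within the scatter), so the clear step seen on the core of compound 1 does not recur on the core of compound 3. The two occurrences differ by more than scatter: the same change on two cores in this assay, a 3.7-fold lower number (0.57 log units; beyond the scatter) from compound 1 to compound 2 and a 1.0-fold lower number (0.01 log units; within the scatter) from compound 3 to compound 4, 3.6-fold (0.55 log units) apart, beyond the scatter of two such steps. This shows that the size of the step cannot be carried from one core to the other in this series, but with a single pair on each core it does not show which difference between the pairs matters, as the core, the side chain and the fluoro group already on the ring of compound 3 all change together.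

Still open, as far as these compounds go, is whether the 4-fluorophenyl to 2,4-difluorophenyl change would give a clear step on the core of compound 1, with the rest of that compound held constant. Also open, from the compounds shown here alone, is how chloro, a nitrile or an amine would compare with fluoro at the same place on either core.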